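The source may report more compounds than this note shows. Statements on the series, on what has been measured and on what is new or still open speak of the compounds shown alone.

Compound 2 `COC(=O)c1sc2cc(C#Cc3ccc(N)cc3)cnc2c1N` gives, in a functional assay on NCI-H460 cells (Homo sapiens) for inhibition, read by sulforhodamine B assay, with a stated time of 48 h (on this read-out higher numbers stand for weaker inhibition of growth and lower numbers for stronger inhibition of growth), a reading of 8900 nM, the lowest of the three numbers shown, though the others sit within the scatter of it: compound 1 `COC(=O)c1sc2cc(C#Cc3cccc(N)c3)cnc2c1N` gives 11500 nM and compound 3 `COC(=O)c1sc2cc(C#Cc3ccc(N(C)C)cc3)cnc2c1N` gives 16600 nM. Compound 4 `COC(=O)c1sc2cc(C#Cc3ccsc3)cnc2c1N` has not been measured; it differs from compound 2 by thiophen-3-yl in place of 4-aminophenyl on a triple-bonded carbon. Within the data shown here, two measured steps touch the same group on the triple-bonded carbon. The first, a 1.3-fold lower number from compound 1 to compound 2 (0.11 log units; within the scatter), moved only the amino around the ring. The second, a 1.9-fold higher number from compound 2 to compound 3 (0.27 log units; within the scatter), altered only the substituent on that ring. Among the measured compounds shown here, neither step removed the six-membered ring itself or its hydrogen-bond donor, so no measured step covers the change to compound 4 directly; both were within the scatter, which suggests this part of the molecule is tolerant of modification. Compound 4 is therefore expected to stay close to compound 2, with the step of a 1.3-fold higher number from compound 2 to compound 4 (0.13 log units; within the scatter) estimated to lie within the scatter. Compound 4 is estimated at 12000 nM, in a range from 5000 nM to 30000 nM.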

Compound 4, concentration for 50% growth inhibition: 24800 nM
The estimate for compound 4 lay 2.1-fold (0.32 log units) below the measured number; the range from low to high includes it.
By their numbers in this assay, from the lowest: compounds 2, 1, 3 and 4 (each within the scatter of the next, the first and the last beyond it).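

Among these compounds, replacing the aminophenyl group with thiophen-3-yl on the triple-bonded carbon gives a 2.8-fold higher number from compound 2 to compound 4 (0.45 log units; beyond the scatter) and a 2.2-fold higher number from compound 1 to compound 4 (0.33 log units; beyond the scatter) in this assay and, though modest, these are the first steps at this place to go beyond the scatter, so the tolerance seen so far does not extend to every change here. The exchange alters the ring size, brings in sulfur and removes the amino group all at once, so these compounds cannot show which of these differences matters. Nothing available here explains the shift.

On these data alone, it remains open whether an unsubstituted phenyl ring on the triple-bonded carbon would read like compound 2 or like compound 4. Also open, as far as these compounds go, is whether an amine placed on the thiophene ring would bring the number back towards that of compound 2.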